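This account rests on a few compounds, and the source may have more. Where it says the series, first, only, none or still open, it means among the compounds named here.

Compound 1 `CC(C)CCn1ccc(-c2ccc(Oc3cccnc3)cc2)c(C#N)c1=O` reaches 231% in a functional assay on CHO cells for positive allosteric modulation of metabotropic glutamate receptor 2 (Homo sapiens), read by scintillation counting and GTPgammaS binding, with a stated time of 30 min; a lower number here means a smaller maximal response, a higher number a larger maximal response. Compound 3 `Cc1ncccc1Oc1ccc(-c2ccn(CCC(C)C)c(=O)c2C#N)cc1` gives 256% in this assay. The two differ by one change, (methyl in place of hydrogen on an aromatic carbon), and the step of a number 25 percentage points higher from compound 1 to compound 3 (beyond the scatter) is counted as beyond the scatter.

Compound 2 `CCCCn1ccc(-c2ccc(Oc3cccnc3C)cc2)c(C#N)c1=O` gives 228% in this assay. How its core differs from the core of compound 1 is not broken down here; the two hold the same atoms joined differently, and their values lie within the scatter of each other. Compound 3 also stands one change away from compound 2, and the step of a number 28 percentage points higher from compound 2 to compound 3 (beyond the scatter) is beyond the scatter, so compound 3 carries the largest response of the three measured compounds.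

Compound 4 `CCCCn1ccc(-c2ccc(Oc3ccc(C)nc3C)cc2)c(C#N)c1=O` has not yet been measured. It differs from compound 2 by methyl in place of hydrogen on an aromatic carbon. This is the same kind of change as that from compound 1 to compound 3, but not the same: in compound 3 the entering methyl sits next to the ring nitrogen and ortho to a large group, whereas in compound 4 it sits next to the ring nitrogen, meta to a methyl group and para to a large group. With the place differing in this way, the expected step is smaller than a number 25 percentage points higher from compound 1 to compound 3 (beyond the scatter). The step from compound 2 to compound 4 is estimated at a number 12 percentage points higher from compound 2 to compound 4 (beyond the scatter), resting on the response of compound 2 at 228%. Compound 4 is therefore expected to reach about 240% in this assay, somewhere between 205% and 275%.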

Compound 4, largest response reached (Emax), in percent of the reference or control that the assay uses: 239%
Estimate against measurement, compound 4: 1 percentage points above; the measured number falls inside the stated range.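

In this assay, among these compounds, methyl in place of hydrogen on an aromatic carbon comes with a number 11 percentage points higher from compound 2 to compound 4 (beyond the scatter), so the change goes with a larger maximal response on the core of compound 2 as well as on the core of compound 1, and the two steps cannot be told apart in size: the same change on two cores in this assay, a number 25 percentage points higher (beyond the scatter) from compound 1 to compound 3 and a number 11 percentage points higher (beyond the scatter) from compound 2 to compound 4, 14 percentage points apart, within the scatter of two such steps Within these two pairs, then, the direction of the step carries from one core to the other, and no compound among them goes against it. Among the compounds shown here, this does not show that the size of the step is fixed, or that the direction would hold on a further core, since there are only two steps and the entering methyl does not sit at the same place on the ring in both, so any influence of the core cannot be separated from that of the place.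

The compounds shown leave open whether an ethyl group, a methoxy group, a chlorine atom or an amine at the place of the entering methyl would go with a similar response. They also leave open what the 2,6-dimethylpyridin-3-yl group would give when joined to the chain of compound 3.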